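Working notes: from compound 3 to compound 4

The source may report more compounds than this note shows. Statements on the series, on what has been measured and on what is new or still open speak of the compounds shown alone.

Measured so far in an ADME assay on J774.A1 cells (Mus musculus) for cytotoxicity, read by MTT assay, with a stated time of 48 h (a lower number here means that less compound is tolerated, a higher number that more compound is tolerated), for this series
- compound 1 `COc1cccc(CNC(=O)c2c([N+](=O)[O-])noc2-c2ccc([N+](=O)[O-])cc2)c1` reads "not determined" (no result reported)
- compound 2 `O=C(Nc1ccccc1)c1c([N+](=O)[O-])noc1-c1ccc(Cl)cc1` reads 89300 nM
- compound 3 `O=C(NCc1ccc(F)cc1)c1c([N+](=O)[O-])noc1-c1ccc(Cl)cc1` reads 91900 nM

Compound 3 and compound 2 lie within the scatter of each other, so neither stands apart, and compound 1 offers no number for comparison. Compound 4 `COc1cccc(CNC(=O)c2c([N+](=O)[O-])noc2-c2ccc(Cl)cc2)c1` is still to be measured. Its difference from compound 3 is 3-methoxyphenyl in place of 4-fluorophenyl on a saturated chain carbon bound to an amide-type nitrogen and amounts to 3-methoxybenzyl in place of 4-fluorobenzyl on the amide-type nitrogen.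

Within the data shown here, only one measured step bears on this change, namely a 1.0-fold higher number from compound 2 to compound 3 (0.01 log units; within the scatter) with 4-fluorobenzyl in place of phenyl on that same nitrogen. It is a single step and does not involve 3-methoxybenzyl. Compound 1 does carry 3-methoxybenzyl but has no number, so the data hold no direct reading of that group. No step beyond the scatter is therefore expected in this assay in either direction, though this rests on thin evidence. The expected step is a 1.1-fold lower number from compound 3 to compound 4 (0.06 log units; within the scatter) by this estimate. For compound 4 the estimated value is 80000 nM with an expected range from 40000 nM to 130000 nM on the next measurement.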

Compound 4, half-maximal cytotoxic concentration: 68600 nM
Compound 4: the middle estimate sits 1.2-fold (0.07 log units) above what was measured, within the range that was stated.
By their numbers in this assay, from the lowest: compounds 4, 2 and 3 (each within the scatter of the next).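

Compound 4 gives a number for 3-methoxybenzyl on the amide-type nitrogen in this assay, a reading that compound 1, with the same group on a different core, does not supply. Exchanging 4-fluorobenzyl for this group gives (a 1.3-fold lower number from compound 3 to compound 4 (0.13 log units; within the scatter)), and exchanging phenyl for it gives (a 1.3-fold lower number from compound 2 to compound 4 (0.11 log units; within the scatter)), so the fluorine leaving and the methoxy oxygen entering produce no step beyond the scatter. Phenyl, 4-fluorobenzyl and 3-methoxybenzyl therefore do not separate compound 2, compound 3 and compound 4 in this assay, and no measurement on hand offers an explanation for these readings.

Steps to compound 1 cannot be read, so whether 3-methoxybenzyl reads the same way on the core of compound 1 as on the core of compound 4 remains open. As far as these compounds go, it is also open whether the flat picture at this position holds for an amine, a carboxylic acid or a longer chain on the amide-type nitrogen, as all three compounds with numbers carry only an aromatic ring there, directly or through a single saturated carbon.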